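A Shorter Chlorinated Arm in Place of the Phenethyl Group

The source may hold more compounds than are shown below. What is called first, only, known or untested is meant among the compounds shown, and "the series" means these compounds.

Measured compounds:
compound 1, `CC(=O)OC[C@H]1O[C@@H](n2cnc3c(N)ncnc32)[C@H](O)[C@@H]1O`, gives > 100000 nM in an assay on COS-7 cells for inhibition of sodium/nucleoside cotransporter 2 (Homo sapiens), read by scintillation counting, in the presence of a further agent that is not named here; a higher number here means a weaker inhibitor, a lower number a stronger inhibitor
compound 2, `Nc1ncnc2c1nc(NCCCc1ccccc1)n2[C@@H]1O[C@H](CO)[C@@H](O)[C@H]1O`, gives 536000 nM in this assay

The value of compound 1 is a limit of the assay and not a number: the limit of > 100000 nM in this assay, at which 1 of the 2 values shown sits. Compound 2 therefore stands as the only numbered result in this assay, a weak inhibitor by any reading, with the other entry being a limit.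

Compound 3, `Nc1ncnc2c1nc(NCc1cccc(Cl)c1)n2[C@@H]1O[C@H](CO)[C@@H](O)[C@H]1O`, differs from compound 2 by 3-chlorophenyl in place of phenethyl on a saturated chain carbon bound to a nitrogen on an aromatic ring. Among the compounds with values here, no pair of measured compounds differs in one place, so no measured step shows how such a change moves the readout in this assay. The expectation is a step of no more than the usual scatter, in no firm direction, which is expected to amount to a 1.2-fold lower number from compound 2 to compound 3 (0.08 log units; within the scatter). Compound 3 is estimated at 450000 nM, with a range from 120000 nM to 2000000 nM.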

Compound 3, half-maximal inhibitory concentration: 5400 nM
For compound 3 the middle estimate is 83-fold (1.92 log units) above the measured one; measured number outside the range, below it.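

This position proves far more sensitive than compound 2 alone could show. In this assay, the change from 3-phenylpropyl to 3-chlorobenzyl on the shared core gives a 99-fold lower number from compound 2 to compound 3 (2.00 log units; beyond the scatter), so the arm on this nitrogen can by itself decide whether the compound is a very weak inhibitor or a much stronger one. Nothing among the measurements shown accounts for the size of this step.

The chlorine and the shorter chain enter together, so the compounds shown do not divide the step between them. On these data alone, a plain benzyl group or a 3-chlorophenethyl group would separate the two, and whether an amine or a carboxylic acid on the ring is tolerated at this arm remains open.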